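Carboxy for Cyano on a Diaryl Urea Scaffold

The source may report more compounds than this note shows. Statements on the series, on what has been measured and on what is new or still open speak of the compounds shown alone.

Measured compounds:
compound 1, `N#Cc1ccc(NC(=O)Nc2ccc(F)c(C(F)(F)F)c2)cc1`, gives < 7 uL/min
compound 2, `O=C(Nc1cccnc1)Nc1ccc(F)c(C(F)(F)F)c1`, gives 13 uL/min
compound 3, `O=C(Nc1cnccn1)Nc1cnccn1`, gives 18 uL/min

Three ureas were run in an ADME assay on microsomes from liver (Homo sapiens) for metabolic stability, using NADPH, with a stated time of 60 min; a lower number here means slower removal, a higher number faster removal of the compound. Compound 2 gives 13 uL/min and compound 3 gives 18 uL/min. For compound 1 this assay reports only a limit, < 7 uL/min, and not a number. Compound 1 thus stands at the limit of < 7 uL/min in this assay, at which 1 of the 3 values shown sits, the floor of the values shown, while the other two compounds return numbers. Among the compounds with values here, no two measured compounds differ from each other in a single place, so no measured step is available to calibrate the change considered next.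

Compound 4, `O=C(Nc1ccc(C(=O)O)cc1)Nc1ccc(F)c(C(F)(F)F)c1`, has not yet been measured in this assay. It differs from compound 1 in one place: carboxy in place of cyano on an aromatic carbon. Within the data shown here, with no measured step of this kind, the expectation can rest only on compound 1 and its < 7 uL/min. The step is expected to be a step that the limit leaves unreadable from compound 1 to compound 4, none beyond the usual scatter. Compound 4 is therefore estimated at 6 uL/min, within a range from 3 uL/min to 14 uL/min, with a real chance that this assay again returns only a limit rather than a number.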

Compound 4, intrinsic clearance in a liver preparation (reported as CLH), per the amount of preparation that the assay uses: < 7 uL/min
Compound 4 gave a limit, no number; the forecaster's own chance of this, stated with the estimate: 55%; the middle value does not contradict the limit.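

In this assay, compound 1 and compound 4 each return only a limit and not a number, so no step can be read from one to the other: the limit of < 7 uL/min in this assay, at which 2 of the 4 values shown sit.

The compounds shown leave open whether carboxy in place of cyano on an aromatic carbon changes the clearance of compound 4 from that of compound 1 at all.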